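Acrylic acid series: dimethoxy pattern swap on compound 2

This account rests on a few compounds, and the source may have more. Where it says the series, first, only, none or still open, it means among the compounds named here.

Measured compounds in a functional assay on M14 cells (Homo sapiens) for cytotoxicity, read by MTT assay, with a stated time of 72 h; on this read-out higher numbers stand for weaker inhibition and lower numbers for stronger inhibition:
compound 1 `O=C(O)/C(=C/c1c[nH]c2ccc(OCc3ccccc3)cc12)c1ccccc1` gives 95200 nM;
compound 2 `COc1ccc(/C(=C\c2cn(C(C)=O)c3ccc(OCc4ccccc4)cc23)C(=O)O)cc1OC` gives 65500 nM;
compound 3 `CC(=O)n1cc(/C=C(/C(=O)O)c2ccc(OCc3ccccc3)cc2)c2cc(OCc3ccccc3)ccc21` gives 58200 nM.

Compound 2 stands second highest of the three numbers. Its nearest neighbour is compound 3 and its furthest is compound 1, and both of these gaps lie within the scatter, so the three measured compounds cannot be told apart on these data. Among the measured compounds shown here, no step between measured compounds that differ in one place is available.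

Compound 4 `COc1ccc(OC)c(/C(=C\c2cn(C(C)=O)c3ccc(OCc4ccccc4)cc23)C(=O)O)c1` is not yet measured. Against compound 2 it shows the change (2,5-dimethoxyphenyl in place of 3,4-dimethoxyphenyl on a double-bonded chain carbon bound to a carbonyl carbon and a double-bonded chain carbon).

For the measured compounds named here, the data give no step of this kind to lean on. The shared core carries every compound here into the same weak region of this assay, and a rearrangement of the two methoxy groups on the same ring is expected to leave it there. For compound 4 the step from compound 2 is expected to be a 1.1-fold higher number from compound 2 to compound 4 (0.03 log units; within the scatter), none beyond the scatter. Compound 4 is estimated at 70000 nM, with a range from 35000 nM to 140000 nM.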

Compound 4, half-maximal inhibitory concentration: 87100 nM
Compound 4: the middle estimate sits 1.2-fold (0.09 log units) below what was measured; the measured number falls inside the stated range.
By their numbers in this assay, from the lowest: compounds 3, 2, 4 and 1 (each within the scatter of the next).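

In this assay, the position on a double-bonded chain carbon bound to a carbonyl carbon and a double-bonded chain carbon now has its first readable step: 2,5-dimethoxyphenyl in place of 3,4-dimethoxyphenyl (a 1.3-fold higher number from compound 2 to compound 4 (0.12 log units; within the scatter)). With the same atoms joined differently, this rearrangement of the two methoxy groups gives no change that can be told from the scatter, so the pair does not show that this pattern matters in this assay. No measurement bears on the reason for this result.

On these data alone, whether any group at this position can move the number beyond the scatter remains open. An amine or a longer chain on this phenyl ring in place of the methoxy groups would test that.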